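A second methoxy on compound 2

The compounds below may be only part of what the source reports. "The series", "measured", "known", "first", "only" and "open" are said of these compounds alone.

In a functional assay on the whole organism with Rattus norvegicus as the target (a lower number here means that less compound is needed, a higher number that more compound is needed for the effect), compound 1 `CCOC(=O)C(=O)Nc1nc(-c2cccc(O)c2)cs1` gives > 10 mg/kg, which is a limit and not a number. Compound 2 `CCOC(=O)C(=O)Nc1nc(-c2cccc(OC)c2)cs1` gives about 20 mg/kg, the higher of the two actual numbers, and compound 3 `CCOC(=O)C(=O)Nc1nc(-c2ccc(OC)c(OC)c2)cs1` gives about 3 mg/kg. Compound 4 `CCOC(=O)C(=O)Nc1nc(-c2cc(OC)cc(OC)c2)cs1` arises from compound 2 through one change, methoxy in place of hydrogen on an aromatic carbon, meta to a large group and meta to a methoxy group. For the measured compounds named here, the closest precedent, also a methoxy added to an aromatic carbon but at a different place, is a 6.7-fold lower number from compound 2 to compound 3 (0.82 log units; beyond the scatter). The other step, a step that the limit leaves unreadable from compound 1 to compound 2, offers no size to use. Only part of the precedent is expected to carry over, giving an estimated 2.5-fold lower number from compound 2 to compound 4 (0.40 log units; beyond the scatter). Compound 4 is expected at 8 mg/kg, with an estimated range of 2.5 mg/kg to 25 mg/kg.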

Compound 4, dose for half-maximal effect: about 10 mg/kg
Compound 4: middle estimate off by 1.3-fold (0.10 log units), on the low side; measured number inside the range.
By their numbers in this assay, from the lowest: compound 3; then compounds 4 and 2 (each within the scatter of the next).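

In this assay, a methoxy in place of hydrogen at this position, meta to a large group and meta to a methoxy group, gives a 2.0-fold lower number from compound 2 to compound 4 (0.30 log units; within the scatter) and so leaves no readable change. The same group at another place on the ring gives a 6.7-fold lower number from compound 2 to compound 3 (0.82 log units; beyond the scatter) and stands out from the scatter. A second methoxy is therefore not enough in itself: in these compounds, where it sits counts. From the compounds shown here alone, whether an amine or an ethoxy at this position would give a clear step stays open. Nothing shown tells why the two places differ.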